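From Dipropylamino to Diethylamino on Compound 2

This account rests on a few compounds, and the source may have more. Where it says the series, first, only, none or still open, it means among the compounds named here.

Measured compounds:
- compound 1 `CCC1CCN(CC(=O)OCCn2c([N+](=O)[O-])cnc2C)CC1`: 0.775 h
- compound 2 `CCCN(CCC)Cc1cccc(C(=O)OCCOCn2cnc3c(=O)[nH]c(N)nc32)c1`: 0.0133 h
- compound 3 `CCCCC(=O)OCOC(=O)Cc1c(C)n(C(=O)c2ccc(Cl)cc2)c2ccc(OC)cc12`: 2.07 h

The three measured compounds were run in an ADME assay on a cell-free system (plasma, Homo sapiens) for metabolic stability; a higher number here means that the compound lasts longer, a lower number that the compound disappears faster. Compound 3 gives 2.07 h, compound 1 gives 0.775 h, and compound 2 gives 0.0133 h, the shortest half-life of the three. The gap from compound 2 to compound 1 lies beyond the scatter, and the gap from compound 2 to compound 3 is wider still. The three compounds share no common core, so none of these gaps can be read as a single structural step.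

Compound 4 `CCN(CC)Cc1cccc(C(=O)OCCOCn2cnc3c(=O)[nH]c(N)nc32)c1` has not yet been measured. It differs from compound 2 in one place only: diethylamino in place of dipropylamino on a saturated chain carbon bound to an aromatic carbon. The rest of the molecule, including the ester and the core beyond it, is unchanged.

For the measured compounds named here, no measured pair in this set isolates a change of this kind, so there is no step to lean on. The difference is a small one, two fewer carbon atoms on the amine, and compound 2 already sits at the short end of the series. The step from compound 2 to compound 4 in this assay is expected to fall within the scatter, a 1.0-fold lower number from compound 2 to compound 4 (0.01 log units; within the scatter), with no direction beyond it. Compound 4 is therefore estimated at 0.013 h, with a range from 0.005 h to 0.035 h.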

Compound 4, half-life: 0.125 h
For compound 4 the middle estimate is 9.6-fold (0.98 log units) below the measured one, and the stated range ends below it.
By their numbers in this assay, from the lowest: compound 2; then compound 4; then compound 1; then compound 3.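

In this assay, the group on the saturated chain carbon bound to an aromatic carbon turns out to bear on the half-life: diethylamino in place of dipropylamino gives a 9.4-fold higher number from compound 2 to compound 4 (0.97 log units; beyond the scatter), with the ester and the core beyond it unchanged. For the compounds shown here, the earlier compounds share no core and could show only how far apart their values lie, whereas this is the first step that isolates one change, and it shows that a change confined to the amine is enough to carry a compound beyond the scatter. Nothing at hand explains why diethylamino goes with the longer half-life here.

What the compounds shown leave open is whether this single step marks a trend along the amine, since it gives no reading for dimethylamino, for dibutylamino or for an amine carrying a single propyl chain. It also leaves open whether the same exchange would give a step of similar size on the core of compound 1 or of compound 3, or with a carboxylic acid in place of the ester.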